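Working notes: amino in place of hydrogen, compound 3 to compound 4

A few compounds are considered here, and "the series" means these few. Any claim that something is new, unique, unknown or untested is made for them only; others in the source may bear on it.

Measured compounds:
- Compound 1 `ClCc1ccccc1Cn1cnc2c(Cl)nc(Cl)nc21`; in a functional assay on MDA-MB-435 cells (Homo sapiens) for cytotoxicity, read by sulforhodamine B assay, with a stated time of 48 h (on this read-out lower numbers stand for stronger inhibition of growth and higher numbers for weaker inhibition of growth), compound 1 gives 3230 nM
- Compound 2 `Nc1nc(Cl)c2ncn(Cc3ccc(CCl)cc3)c2n1`; in this assay compound 2 gives 42700 nM
- Compound 3 `ClCc1ccccc1Cn1cnc2c(Cl)ncnc21`; in this assay compound 3 gives 9550 nM

Compound 3 holds the second highest number of the three: lower than compound 2, higher than compound 1. Among the measured compounds shown here, the one single-point step on record, a 3.0-fold higher number from compound 1 to compound 3 (0.47 log units; beyond the scatter), shows that removing the chloro from the shared core costs potency on this read-out.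

Compound 4 `Nc1nc(Cl)c2ncn(Cc3ccccc3CCl)c2n1` differs from compound 3 by amino in place of hydrogen on an aromatic carbon. For the measured compounds named here, no measured pair isolates this exact change. The only bearing is indirect: compound 2, which already carries the amino together with the chloro on the same core but with the chloromethyl group at a different position on the benzyl ring, shows the highest number of the set, well above compound 3. Since that comparison also shifts the benzyl substitution, it gives direction more than size. The expectation is therefore a further move to a higher number in this assay, of modest to clear size, with wide uncertainty.

Compound 4 is estimated at 20000 nM, within 6000 nM to 60000 nM, corresponding to an expected step of a 2.1-fold higher number from compound 3 to compound 4 (0.32 log units; beyond the scatter).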

Compound 4, concentration for total growth inhibition: 26900 nM
The estimate for compound 4 lay 1.3-fold (0.13 log units) below the measured number; the range from low to high includes it.
By their numbers in this assay, from the lowest: compound 1; then compound 3; then compounds 4 and 2 (each within the scatter of the next).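

In this assay the aromatic carbon carrying the chloro group in compound 1 now has three substituents on record: amino in place of hydrogen brings a 2.8-fold higher number from compound 3 to compound 4 (0.45 log units; beyond the scatter) and amino in place of chloro brings an 8.3-fold higher number from compound 1 to compound 4 (0.92 log units; beyond the scatter) on the shared core. All steps at this carbon lie beyond the scatter, so across compounds 1, 3 and 4 the number rises in the order chloro, hydrogen, amino. Compound 4 at 26900 nM and compound 2 at 42700 nM stand within the scatter of each other, so with amino on the core the different place of the chloromethyl group on the benzyl ring gives no readable change.

As far as these compounds go, whether a methylamino, hydroxyl or methoxy group at this carbon would track with chloro or with amino stays open. Nothing on hand accounts for the size of these steps.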